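The source may hold more compounds than are shown below. What is called first, only, known or untested is meant among the compounds shown, and "the series" means these compounds.

In a functional assay on CWR22R cells (Homo sapiens) for antiproliferative activity, read by propidium iodide staining, with a stated time of 96 h (a higher number here means a weaker inhibitor, a lower number a stronger inhibitor), compound 1 `CC(O)(CSc1cccc(S(F)(F)(F)(F)F)c1)C(=O)Nc1ccc([N+](=O)[O-])c(C(F)(F)F)c1` gives 8800 nM while compound 2 `CC(O)(CSc1ccc(S(F)(F)(F)(F)F)cc1)C(=O)Nc1ccc(C#N)cc1C(F)(F)F` gives 13200 nM and compound 3 `CC(O)(CSc1ccc(S(F)(F)(F)(F)F)cc1)C(=O)Nc1ccc(S(F)(F)(F)(F)F)cc1` gives 24400 nM on the same read-out. Compound 3 and compound 2 sit within the scatter of each other, whereas compound 3 has a higher number than compound 1 by a gap beyond the scatter.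

Compound 4 `CC(O)(CSc1ccc(F)cc1)C(=O)Nc1ccc(S(F)(F)(F)(F)F)cc1` differs from compound 3 in one place, and the change is one fluorine atom in place of a group of 6 heavy atoms (5 fluorine, 1 sulfur; no ring), on an aromatic carbon on an aromatic carbon of a six-membered aromatic ring of carbon only, para to a large group. Among the measured compounds shown here, no two measured compounds differ in one place only, so the data give no direct measure of this swap. With compound 1 at 8800 nM and compound 3 at 24400 nM as the ends of the measured span, no change beyond the scatter is expected in either direction. The expected step is a 1.2-fold lower number from compound 3 to compound 4 (0.09 log units; within the scatter) and it stays within the scatter. Compound 4 is estimated at 20000 nM with a range from 8000 nM to 50000 nM for this expectation.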

Compound 4, half-maximal inhibitory concentration: 13500 nM
For compound 4 the middle estimate is 1.5-fold (0.17 log units) above the measured one; measured number inside the range.
By their numbers in this assay, from the lowest: compounds 1, 2, 4 and 3 (each within the scatter of the next, the first and the last beyond it).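

Among the compounds shown here, this is the first pair that differs in one place only, so the group at this position can now be judged on its own. In this assay, replacing the group of 6 heavy atoms (5 fluorine, 1 sulfur), para to a large group on the aromatic ring, with fluoro gives a 1.8-fold lower number from compound 3 to compound 4 (0.26 log units; within the scatter), so this one pair shows no change beyond the scatter despite the much smaller group. No accompanying measurement bears on this result, so the data offer no explanation for it.

On these data alone, it remains open whether a methoxy group, an amine or a carboxylic acid at this position would also stay within the scatter. It is also unknown whether the same swap would read alike on the core of compound 2, which carries a nitrile and a trifluoromethyl group on its other ring.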